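The source may hold more compounds than are shown below. What is called first, only, known or untested is meant among the compounds shown, and "the series" means these compounds.

Values in an ADME assay on the whole organism (strain CD-1) for pharmacokinetics, with Mus musculus as the target, at a dose of 3 mg/kg by the intravenous route (a lower number here means less compound in the circulation, a higher number more compound in the circulation at the dose given), for the compounds measured so far

compound 1 `CC(CCCCOc1ccccc1CN(C)C(=O)c1ccc(-c2ccco2)cc1)C(=O)O` gives 11400 ng.h/mL
compound 2 `C[C@@H](CCCOc1ccccc1CN(C)C(=O)c1ccc(-c2ccco2)cc1)CC(=O)O` gives 30800 ng.h/mL
compound 3 `CN(Cc1ccccc1OCCC/C=C/C(=O)O)C(=O)c1ccc(-c2ccco2)cc1` gives 750 ng.h/mL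

Compound 3 has the lowest number of the three. Compound 4 `C/C(=C\CCCOc1ccccc1CN(C)C(=O)c1ccc(-c2ccco2)cc1)C(=O)O` differs from it by 2-carboxyprop-1-en-1-yl in place of 2-carboxyethenyl (2-carboxyprop-1-en-1-yl in place of 2-carboxyethenyl on a saturated chain carbon, three bonds along the chain from an oxygen on an aromatic ring) on a saturated chain carbon, three bonds along the chain from an oxygen on an aromatic ring. Within the data shown here, no measured step makes this exact change. Two large steps bear on it (a 15-fold lower number from compound 1 to compound 3 (1.18 log units; beyond the scatter)) and (a 41-fold lower number from compound 2 to compound 3 (1.61 log units; beyond the scatter)). Compound 4 keeps the double bond of compound 3, but its carbon skeleton matches the 2-carboxypropyl of compound 1 (11400 ng.h/mL), so only a partial recovery seems likely. A modest rise is therefore expected (a 3.3-fold higher number from compound 3 to compound 4 (0.52 log units; beyond the scatter)). In this assay the estimate for compound 4 is 2500 ng.h/mL (range 700 ng.h/mL to 9000 ng.h/mL) as an expected value.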

Compound 4, area under the concentration-time curve: 1300 ng.h/mL
The estimate for compound 4 lay 1.9-fold (0.28 log units) above the measured number, within the range that was stated.
By their numbers in this assay, from the lowest: compounds 3 and 4 (each within the scatter of the next); then compound 1; then compound 2.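

In this assay, the step of a 1.7-fold higher number from compound 3 to compound 4 (0.24 log units; within the scatter) shows that the extra carbon of 2-carboxyprop-1-en-1-yl does not bring back the higher numbers. Among these compounds, the double bond is the one difference in the step of an 8.8-fold lower number from compound 1 to compound 4 (0.94 log units; beyond the scatter) and the step of a 24-fold lower number from compound 2 to compound 4 (1.37 log units; beyond the scatter) points the same way, though it also moves the carboxylic acid along the chain and shifts the methyl branch. Nothing measured here explains this drop. On these data alone, it remains open whether a triple bond or a cyclopropane ring at this place in the chain would go with the lower numbers or the higher numbers.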